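A few compounds are considered here, and "the series" means these few. Any claim that something is new, unique, unknown or untested is made for them only; others in the source may bear on it.

The series at hand is measured in a functional assay on MDA-MB-231 cells (Homo sapiens) for inhibition, read by sulforhodamine B assay, with a stated time of 72 h; a lower number here means a stronger inhibitor of growth, a higher number a weaker inhibitor of growth. Compound 1 `O=C(O)/C=C/c1ccncc1-c1ccc2cc[nH]c2c1` returns only a limit there, > 10000 nM. Compound 3 `NNC(=O)CCc1ccncc1-c1ccc2ccccc2c1` likewise reaches no number and gives only a limit, > 10000 nM. Compound 2 `CNC(=O)/C=C/c1ccncc1-c1ccc2c(cnn2C)c1`, the starting point of the step followed here, also stands at a limit in this assay, > 10000 nM. Every measured value sits at the same place, (the limit of > 10000 nM in this assay, at which 3 of the 3 values shown sit), so the measured set separates none of these compounds from the others, and no step between measured compounds can be read from it. Compound 4 `CCOC(=O)/C=C/c1ccncc1-c1ccc2c(cnn2C)c1` has not yet been measured in this assay. It differs from compound 2 in a single place: ethoxy in place of methylamino on a carbonyl carbon. The methylamino that leaves carried the only hydrogen-bond donor of that part of the molecule, and the ethoxy that enters brings none. With nothing but limits to build on, the step expected in this assay is a step that the limit leaves unreadable from compound 2 to compound 4, none beyond the scatter. Compound 4 is therefore estimated at about 20000 nM in this assay, within a range of 7000 nM to 60000 nM, and most probably reported once more only as a limit.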

Compound 4, concentration for 50% growth inhibition: > 10000 nM
Compound 4 was reported as a limit (the forecaster's own chance of this, stated with the estimate: 85%); the middle value does not contradict the limit.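

Compound 2 and compound 4 both stand at a limit, so no step can be read from one to the other: the limit of > 10000 nM in this assay, at which 4 of the 4 values shown sit.
The compounds shown leave open whether ethoxy or methylamino on that carbonyl carbon makes any difference in this assay, where none of them reaches a number.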